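Hydroxy in place of dimethylamino: expected effect on proliferation

The source may report more compounds than this note shows. Statements on the series, on what has been measured and on what is new or still open speak of the compounds shown alone.

Compound 2 `CCCCCCCCCCCCCCCCCCNC(=O)[C@@H]1CSC(c2ccc(N(C)C)cc2)N1` gives 5300 nM in a functional assay on DU-145 cells (Homo sapiens) for antiproliferative activity, read by sulforhodamine B assay; a higher number here means a weaker inhibitor, a lower number a stronger inhibitor. Going by the values given here, this is the lowest of the two numbers measured so far, yet it lies within the scatter of compound 1 `CCCCCCCCCCCCCCCCCCNC(=O)[C@@H]1CSC(c2cccc(O)c2)N1`, which in this assay gives 5700 nM. Among the compounds with values here, the single measured step, a 1.1-fold lower number from compound 1 to compound 2 (0.03 log units; within the scatter), is the only comparison available.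

Compound 3 `CCCCCCCCCCCCCCCCCCNC(=O)[C@@H]1CSC(c2ccc(O)cc2)N1` differs from compound 2 by hydroxy in place of dimethylamino on an aromatic carbon. This change again swaps one aryl substituent for another on the shared core, the same kind of exchange seen in the measured step. Because that step, a 1.1-fold lower number from compound 1 to compound 2 (0.03 log units; within the scatter), stayed within the scatter, no step beyond the scatter is expected in this assay for compound 3 in either direction. Compound 3 is therefore expected to give about 5500 nM, with a range of 2500 nM to 12000 nM. The expected step is thus a 1.0-fold higher number from compound 2 to compound 3 (0.02 log units; within the scatter), a change not beyond the scatter.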

Compound 3, half-maximal inhibitory concentration: 3100 nM
For compound 3 the middle estimate is 1.8-fold (0.25 log units) above the measured one; low and high end bracket the measured number.
By their numbers in this assay, from the lowest: compounds 3, 2 and 1 (each within the scatter of the next).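

In this assay, hydroxy in place of dimethylamino on an aromatic carbon, para to a large group, gives a 1.7-fold lower number from compound 2 to compound 3 (0.23 log units; within the scatter) and does not separate the two substituents at this position. The earlier step changed both the group and its place on the ring, whereas this one changes the group alone; the comparison of the two hydroxy placements gives a 1.8-fold lower number from compound 1 to compound 3 (0.26 log units; within the scatter) and does not separate 4-hydroxyphenyl from 3-hydroxyphenyl either. No data at hand bear on the origin of these steps.

Going by these compounds, whether a methoxy group, an amine or a carboxylic acid on this aromatic carbon would give a step beyond the scatter remains open. Also open is how far the numbers depend on the long alkyl chain, since a shorter chain does not appear among these compounds.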